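Fluoro in place of hydrogen: what compound 4 may give

A few compounds are considered here, and "the series" means these few. Any claim that something is new, unique, unknown or untested is made for them only; others in the source may bear on it.

Compound 1 `c1ccc(N2CCN(CCCCCOc3ccc4c(c3)CCC4)CC2)cc1`: 25%
Compound 2 `Fc1ccc(N2CCN(CCCCCOc3ccc4c(c3)CCC4)CC2)cc1`: 71%
Compound 3 `O=[N+]([O-])c1cc2c(cc1OCCCN1CCN(c3ccccc3)CC1)CCC2`: 24%

These three compounds have been measured in a functional assay on the whole organism for inhibition, with Mus musculus as the target, at a dose of 25 mg/kg by the oral route; a higher number here means more inhibition at the dose given (going by the name of the read-out), a lower number less inhibition. Compound 1 and compound 2 share a core and differ by fluoro in place of hydrogen on an aromatic carbon; this change gives a number 46 percentage points higher from compound 1 to compound 2 (beyond the scatter). Compound 3 carries a different core, and the difference between the two cores is not broken down here. Compound 3 and compound 1 give numbers within the scatter of each other.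

Compound 4 `O=[N+]([O-])c1cc2c(cc1OCCCN1CCN(c3ccc(F)cc3)CC1)CCC2` differs from compound 3 by fluoro in place of hydrogen on an aromatic carbon, the same change that was made from compound 1 to compound 2. A step of a number 31 percentage points higher from compound 3 to compound 4 (beyond the scatter) is expected in this assay, because the matching change gave a number 46 percentage points higher from compound 1 to compound 2 (beyond the scatter). The different core of compound 3 leaves room for doubt. Compound 4 is therefore estimated at 55%, between 28% and 80%.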

Compound 4, a percentage reported as inhibition, in the whole organism at one dose (the size of the read-out at that dose, not a potency): 28%
Compound 4: middle estimate off by 27 percentage points, on the high side; the measured number falls inside the stated range.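

In this assay, fluoro in place of hydrogen gives a number 4 percentage points higher from compound 3 to compound 4 (within the scatter), so the gain seen on the core of compound 1 does not carry over to the core of compound 3. The two steps differ: the same change on two cores in this assay, a number 46 percentage points higher (beyond the scatter) from compound 1 to compound 2 and a number 4 percentage points higher (within the scatter) from compound 3 to compound 4, 42 percentage points apart, beyond the scatter of two such steps

This shows that, in this series, the step from phenyl to 4-fluorophenyl cannot be read from one core to the other. Among these compounds, it does not show which part of the difference between the cores is responsible, and each core offers only a single pair.

The compounds shown leave open whether chloro or methoxy in place of the fluoro would follow the same split between the two cores. They also leave open whether a longer chain would change the step on the core of compound 3.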